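The source may hold more compounds than are shown below. What is called first, only, known or untested is meant among the compounds shown, and "the series" means these compounds.

Going by the values given here, compound 1, with the structure `N=C(N)N/N=C/c1cccc(C(=N)N)c1`, gives the lowest of the two numbers so far in an assay for inhibition of S-adenosylmethionine decarboxylase proenzyme (Rattus norvegicus) (on this read-out lower numbers stand for stronger inhibition and higher numbers for weaker inhibition), where compound 1 gives 36 nM. Among the compounds with values here, its only neighbour is compound 2, `N=C(N)N/N=C/c1cccc(C(N)=O)c1`, which gives 20000 nM in this assay; the step of a 560-fold higher number from compound 1 to compound 2 (2.74 log units; beyond the scatter) is a large one, and it concerns the amidine end of the molecule, not the guanidine end. Compound 3, `N=C(NO)N/N=C/c1cccc(C(=N)N)c1`, is not yet measured in this assay. It differs from compound 1 by hydroxy in place of hydrogen on an amine nitrogen, and the same difference cut one bond further out reads amino to hydroxyamino. Within the data shown here, no measured step touches the guanidine end, so the one known step gives no direct guide to the size of this change; it shows only that the amidine that compound 3 keeps unchanged matters greatly. Among the measured compounds shown here, with no step bearing on the change itself, compound 3 is expected to stay near compound 1, with a step of a 2.8-fold higher number from compound 1 to compound 3 (0.44 log units; beyond the scatter) in this assay allowed either way but most likely a modest loss. The estimate for compound 3 is therefore 100 nM, with a range from 20 nM to 600 nM.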

Compound 3, half-maximal inhibitory concentration: 92 nM
Compound 3: middle estimate off by 1.1-fold (0.04 log units), on the high side; measured number inside the range.
By their numbers in this assay, from the lowest: compound 1; then compound 3; then compound 2.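

In this assay, going by these compounds alone, the step of a 2.6-fold higher number from compound 1 to compound 3 (0.41 log units; beyond the scatter) gives the first reading of a change on an amine nitrogen, and it is a modest one: hydroxy in place of hydrogen there weakens inhibition measurably but leaves compound 3 as an inhibitor with a number far closer to that of compound 1 than to the other neighbour's. Set against the step of a 560-fold higher number from compound 1 to compound 2 (2.74 log units; beyond the scatter) at the amidine, the change on the amine nitrogen is much the smaller of the two known changes to compound 1, so among these compounds the amidine is the more demanding of the two places. Nothing measured here bears on why hydroxy costs this much.

The compounds shown leave open whether a larger group on the same amine nitrogen, such as methoxy or methyl, or an amino group in place of the hydroxy, would give a similar modest step or a larger one. They also leave open whether a group other than the amide in place of the amidine, such as an amine or a carboxylic acid, would keep any of the inhibition seen with compound 1.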